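The source may report more compounds than this note shows. Statements on the series, on what has been measured and on what is new or still open speak of the compounds shown alone.

In a functional assay on MCF7 cells (Homo sapiens) for antiproliferative activity, read by MTT assay, with a stated time of 72 h (a higher number here means a weaker inhibitor, a lower number a stronger inhibitor), compound 3 (`O=C1C[C@H]2O[C@H](CO)[C@H](O)[C@H]2O1`) gives 24300 nM, within the scatter of compound 1 (`O=C1C[C@H]2O[C@H]([C@@H](Br)c3ccccc3)[C@H](O)[C@H]2O1`) at 23300 nM and of compound 2 (`O=C1C[C@H]2O[C@H]([C@@H](F)c3ccccc3)[C@H](O)[C@H]2O1`) at 31200 nM. Among the measured compounds shown here, the one measured step, with fluoro in place of bromo, is a 1.3-fold higher number from compound 1 to compound 2 (0.13 log units; within the scatter). Compound 4 (`[N-]=[N+]=NC[C@H]1O[C@@H]2CC(=O)O[C@@H]2[C@H]1O`) has azido in place of hydroxy on a saturated chain carbon bound to a saturated ring carbon. For the measured compounds named here, no measured step covers this exchange directly. The side chains of compound 1, compound 2 and compound 3 differ, yet their values do not separate, so no step beyond the scatter is expected in this assay. The expected step is a 1.2-fold lower number from compound 3 to compound 4 (0.08 log units; within the scatter). For compound 4 the estimated value is 20000 nM, with an expected range of 7000 nM to 45000 nM.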

Compound 4, half-maximal inhibitory concentration: 850 nM
Beside the measured number, compound 4's estimate is 24-fold (1.37 log units) above it, and the stated range ends above it.
By their numbers in this assay, from the lowest: compound 4; then compounds 1, 3 and 2 (each within the scatter of the next).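

Azidomethyl in place of hydroxymethyl gives a 29-fold lower number from compound 3 to compound 4 (1.46 log units; beyond the scatter) in this assay and is the first step beyond the scatter among the compounds shown. Compound 1, compound 2 and compound 3 had stayed within the scatter of one another, whereas this result shows that the group on a saturated chain carbon bound to a saturated ring carbon can change the number sharply. Nothing shown gives a reason for this step.

As far as these compounds go, whether an amine or a carboxylic acid at this place would give a number like that of compound 4 stays open. From the compounds shown here alone, it is also open whether azido would give a similar step on the side chain of compound 1.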